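A Single Fluoro Added to Compound 1

A few compounds are considered here, and "the series" means these few. Any claim that something is new, unique, unknown or untested is made for them only; others in the source may bear on it.

- compound 1 `CN(C)C(=O)c1cc2cnc(Nc3ccc(NC(=O)C4(C(=O)Nc5ccc(F)cc5)CC4)cc3)nc2n1C1CCCC1`: 79.7%
- compound 2 `CN(C)C(=O)c1cc2cnc(Nc3ccc(NC(=O)C4(C(=O)Nc5ccc(Cl)c(C(F)(F)F)c5)CC4)cc3)nc2n1C1CCCC1`: 48%
- compound 3 `CN(C)C(=O)c1cc2cnc(Nc3ccc(NC(=O)C4(C(=O)Nc5cccc(Br)c5)CC4)cc3)nc2n1C1CCCC1`: 89.6%

These three compounds share one core and differ only in the aryl group on an amide-type nitrogen. In a functional assay on OVCAR-5 cells (Homo sapiens) for inhibition, read by CCK-8 assay, with a stated time of 72 h, tested at 10 uM (a lower number here means less inhibition of growth, a higher number more inhibition of growth at the concentration tested), compound 1 gives 79.7%, which places it in the upper part of this small set. The nearest neighbour is separated by a number 9.9 percentage points higher from compound 1 to compound 3 (within the scatter), while the furthest lies at a number 31.7 percentage points lower from compound 1 to compound 2 (beyond the scatter).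

The next compound, compound 4 `CN(C)C(=O)c1cc2cnc(Nc3ccc(NC(=O)C4(C(=O)Nc5ccc(F)cc5)CC4)cc3F)nc2n1C1CCCC1`, keeps that aryl group and carries a different edit: fluoro in place of hydrogen on an aromatic carbon. In words, this is fluoro in place of hydrogen on an aromatic carbon, ortho to a large group and meta to a large group.

Going by the values given here, no measured step touches this carbon, so the evidence is indirect. The measured steps show how far this assay can move when the other end of the molecule changes. The largest of them is a number 41.6 percentage points higher from compound 2 to compound 3 (beyond the scatter), and both large steps involve compound 2 and its 4-chloro-3-(trifluoromethyl)phenyl group. Among the compounds with values here, compound 4 keeps the 4-fluorophenyl group of compound 1, so no step of that size is anticipated, although the data cannot rule one out.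

The expected change is a number 4.7 percentage points lower from compound 1 to compound 4 (within the scatter), and no step beyond the scatter is expected. Compound 4 is estimated at 75%, with an expected range from 58% to 89%.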

Compound 4, percent growth inhibition at one concentration: 33%
Estimate against measurement, compound 4: 42 percentage points above; measured number outside the range, below it.
By their numbers in this assay, from the lowest: compound 4; then compound 2; then compounds 1 and 3 (each within the scatter of the next).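

This aromatic carbon, ortho to a large group and meta to a large group, turns out to matter in this assay: fluoro in place of hydrogen, an edit of one heavy atom, gives a number 46.7 percentage points lower from compound 1 to compound 4 (beyond the scatter). The earlier compounds shown here showed a large step only at the aryl group on the amide-type nitrogen, as in a number 31.7 percentage points lower from compound 1 to compound 2 (beyond the scatter), so compound 4 shows that a second part of the molecule can also move this read-out by a large amount, even though the 4-fluorophenyl group stays the same. Nothing in the data given explains why this one added atom has such an effect.

The compounds shown leave open whether the loss belongs to fluoro itself or would follow any group on this carbon, a question that chloro, methyl or methoxy at the same place could help to settle. They also leave open whether fluoro on this carbon would give a step of similar size when combined with the 3-bromophenyl group of compound 3, or whether its effect depends on the aryl group at the other end.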